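The compounds below may be only part of what the source reports. "The series", "measured", "known", "first", "only" and "open" are said of these compounds alone.

Measured in a functional assay on P388 cells (Mus musculus); on this read-out higher numbers stand for an effect only at larger amounts of compound and lower numbers for an effect already at smaller amounts:
- compound 1 `Nc1ncn(C[C@H]2CO[C@H](CO)O2)c(=O)n1` gives 65000 nM
- compound 2 `Cc1nn(C[C@@H]2CO[C@H](CO)O2)c(=O)[nH]c1=O` gives > 100000 nM (a limit)
- compound 3 `Cc1nn(C[C@H]2CO[C@H](CO)O2)c(=O)[nH]c1=O` gives > 100000 nM (a limit)

For the measured compounds named here, compound 1 carries the only actual number, 65000 nM. The rest of the picture is the limit of > 100000 nM in this assay, at which 2 of the 3 values shown sit, and that is a limit of the assay, not a number.

The open question is compound 4 `Nc1ncn(C[C@@H]2CO[C@@H](CO)O2)c(=O)n1`, the mirror image of compound 1: the two compounds have the same atoms and bonds and differ only in configuration as drawn: 2 of 2 stereo elements differ (all stereocentres are inverted: mirror images); a stereocentre at a saturated ring carbon is drawn S in compound 1 and R in compound 4; a stereocentre at a saturated ring carbon is drawn S in compound 1 and R in compound 4.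

Going by the values given here, only one measured step bears on configuration: a step that the two limits leave unreadable from compound 2 to compound 3. It is relevant because of the fact that compounds 2 and 3 differ only in the configuration as drawn, but compound 2 and compound 3 differ at only one of the two stereocentres, and they carry a different ring substituent from compound 1. No size can be taken from this step, and it gives no direction for the full inversion. The expectation therefore rests on compound 1 at 65000 nM, with no step beyond the usual scatter expected in this assay and no direction favoured by the data.

The expected step is a 1.2-fold higher number from compound 1 to compound 4 (0.09 log units; within the scatter). A report of compound 4 as a limit would also be unsurprising, given (the limit of > 100000 nM in this assay, at which 2 of the 3 values shown sit).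

For compound 4 the estimated value is 80000 nM, with an expected range from 30000 nM to 200000 nM.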

Compound 4, half-maximal effective concentration: 70000 nM
The estimate for compound 4 lay 1.1-fold (0.06 log units) above the measured number; measured number inside the range.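

In this assay, inverting both stereocentres gives a 1.1-fold higher number from compound 1 to compound 4 (0.03 log units; within the scatter), so the two mirror images cannot be told apart on this read-out. This is the first comparison of configuration in the series with a number on both sides, and it is a clean one: the fact that compounds 1 and 4 differ only in the configuration as drawn The earlier pair, compound 2 and compound 3, stands at a limit of the assay and its step cannot be read, so the absence of a configuration effect beyond the scatter is shown only for compound 1 and compound 4.

Still open, from the compounds shown here alone, is how a compound with only one of the two stereocentres of compound 1 inverted would read, since a change at one centre could behave differently from the inversion of both. Also open, going by these compounds, is whether configuration stays without effect on the core of compound 1 when a carboxylic acid or a longer chain stands in place of the hydroxymethyl group, and whether the same holds for any compound reading at clearly smaller numbers in this assay.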